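A Furan Ketone Tested Against Breast Cancer Cells

A few compounds are considered here, and "the series" means these few. Any claim that something is new, unique, unknown or untested is made for them only; others in the source may bear on it.

The series shares one core, seen in compound 1 `COc1cc(C(=O)C2Sc3nnc(-c4cc(OC)c(OC)c(OC)c4)n3NC2c2ccco2)cc(OC)c1OC`, compound 2 `COc1cc(-c2nnc3n2NC(c2ccco2)C(C(=O)C2CC2)S3)cc(OC)c1OC` and compound 3 `COc1cc(-c2nnc3n2NC(c2ccco2)C(C(=O)c2ccc(C(F)(F)F)cc2)S3)cc(OC)c1OC`, and differs only in the group attached to a carbonyl carbon. In a functional assay on MCF7 cells (Homo sapiens) for cytotoxicity, read by MTT assay, with a stated time of 48 h (a higher number here means a weaker inhibitor, a lower number a stronger inhibitor), compound 1 gives > 100000 nM, which is a limit of the assay and not a number. Compound 2 likewise gives > 100000 nM in this assay, again a limit. Among the compounds with values here, compound 3 gives 33600 nM in this assay, the only number measured so far; two of the three values sit at the limit of > 100000 nM in this assay, at which 2 of the 3 values shown sit. The step of an at least 2.9-fold lower number from compound 1 to compound 3 (0.47 log units; beyond the scatter) and the step of an at least 2.9-fold lower number from compound 2 to compound 3 (0.47 log units; beyond the scatter) are both beyond the usual scatter, so the 4-(trifluoromethyl)phenyl group on the carbonyl carbon sets compound 3 apart from the 3,4,5-trimethoxyphenyl and cyclopropyl versions. The step from compound 1 to compound 2 is a step that the two limits leave unreadable from compound 1 to compound 2.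

Compound 4 `COc1cc(-c2nnc3n2NC(c2ccco2)C(C(=O)c2ccco2)S3)cc(OC)c1OC` has not yet been tested. It differs from compound 3 in one place: furan-2-yl in place of 4-(trifluoromethyl)phenyl on a carbonyl carbon. Within the data shown here, no measured step involves a furan-2-yl group; the measured steps only show that changing this group can move the value at least modestly, and that the two other groups tried gave limits. The expected step is a 1.8-fold higher number from compound 3 to compound 4 (0.25 log units; within the scatter), a move toward the weaker end. Compound 4 is therefore estimated at 60000 nM in this assay, within 20000 nM to 150000 nM.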

Compound 4, half-maximal inhibitory concentration: > 100000 nM
Compound 4: no number, only a limit; the forecaster's own chance of this, stated with the estimate: 45%; at least 1.6-fold (0.22 log units) between middle value and limit.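

Compound 4 gives > 100000 nM in this assay, which is a limit of the assay and not a number. Putting furan-2-yl in place of 4-(trifluoromethyl)phenyl on the carbonyl carbon gives an at least 2.9-fold higher number from compound 3 to compound 4 (0.47 log units; beyond the scatter), so an aromatic ring at this position does not by itself keep a measurable value; compound 1 had already hinted at this with its 3,4,5-trimethoxyphenyl ring, but only through a limit of its own, and the furan-2-yl result adds a second aromatic ring of a different kind. The steps to compound 4 from compound 1 and compound 2 join limit to limit and cannot be read, which leaves compound 3 as the only one of the four with a number, and the shared limit now reads: the limit of > 100000 nM in this assay, at which 3 of the 4 values shown sit.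

With a single number in the set, the compounds shown cannot tell whether the ring of compound 3 or its trifluoromethyl group is what matters. As far as these compounds go, a plain phenyl ring on the same carbonyl carbon would separate those two, and how a chlorine or a nitrile on that ring would behave remains open.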